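A One-Carbon Extension Among Limit-Bound Values

This account rests on a few compounds, and the source may have more. Where it says the series, first, only, none or still open, it means among the compounds named here.

In a functional assay on HUVEC cells (Homo sapiens) (on this read-out lower numbers stand for an effect already at smaller amounts and higher numbers for an effect only at larger amounts of compound), compound 1 `COC1=C(C)C(=O)/C(=C(O)/C=C/c2ccc(OC)cc2)C(=O)C1(C)C` gives < 4 ug/mL as a limit and not a number. Compound 2 `COC1=C(C)C(=O)/C(=C(O)/C=C/c2ccccc2OC)C(=O)C1(C)C` gives < 4 ug/mL as a limit too. Compound 3 `COC1=C(C)C(=O)/C(=C(O)/C=C/c2ccc(C)cc2)C(=O)C1(C)C`, the starting point of this step, gives < 4 ug/mL as a limit as well. The whole set therefore offers the limit of < 4 ug/mL in this assay, at which 3 of the 3 values shown sit, and no numerical value.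

Compound 4 `CCc1ccc(/C=C/C(O)=C2/C(=O)C(C)=C(OC)C(C)(C)C2=O)cc1` differs from compound 3 by methyl in place of hydrogen on a saturated chain carbon bound to an aromatic carbon and this reads as 4-methylphenyl to 4-ethylphenyl on the shared core. The change is a small one: methyl in place of hydrogen on a saturated chain carbon bound to an aromatic carbon.

The measured steps all concern the aromatic group that changes here, but they give little guidance. Both a step that the two limits leave unreadable from compound 1 to compound 2 and a step that the two limits leave unreadable from compound 2 to compound 3 have no size that can be carried over. Going by a step that the two limits leave unreadable from compound 1 to compound 3 no step beyond the scatter is expected in this assay and no direction can be named. The expected change is a step that the limit leaves unreadable from compound 3 to compound 4 as an estimate resting on these few compounds alone. Compound 4 is expected at an estimated 2 ug/mL with a likely range from 0.6 ug/mL to 4 ug/mL and a good chance of ending up only as a limit.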

Compound 4, concentration for half-maximal effect: < 4 ug/mL
Compound 4 gave a limit, no number (the forecaster's own chance of this, stated with the estimate: 75%); the middle value does not contradict the limit.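

In this assay compound 4 gives < 4 ug/mL, a limit and not a number. Among the compounds shown here, no step from compound 1, compound 2 or compound 3 to compound 4 can be read, because all four compounds share one value: the limit of < 4 ug/mL in this assay, at which 4 of the 4 values shown sit. The compounds shown leave open whether changing the aromatic group alters the effect at all, and by how much.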